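Replacing the ring amine on the shared core with an open chain

This account rests on a few compounds, and the source may have more. Where it says the series, first, only, none or still open, it means among the compounds named here.

Measured so far:
compound 1 `CC(C(=O)NCc1ccc(C(F)(F)F)cc1N1CCCCCC1)c1ccc(NS(C)(=O)=O)c(F)c1` gives 1.6 nM in an assay on CHO cells for antagonist activity at transient receptor potential cation channel subfamily V member 1 (Homo sapiens), read by FLIPR; a higher number here means a weaker inhibitor, a lower number a stronger inhibitor
compound 2 `CC(C(=O)NCc1ccc(C(F)(F)F)cc1N1CCN(c2ccccc2)CC1)c1ccc(NS(C)(=O)=O)c(F)c1` gives 2 nM in this assay

Compound 1 stands at the lowest of the two numbers, with compound 2 within the scatter of it: a 1.3-fold higher number from compound 1 to compound 2 (0.10 log units; within the scatter). Compound 3 `CC(C(=O)NCc1ccc(C(F)(F)F)cc1SCCCO)c1ccc(NS(C)(=O)=O)c(F)c1` differs from compound 1 by (3-hydroxypropyl)sulfanyl in place of azepan-1-yl on an aromatic carbon. Among the compounds with values here, the only measured step at this position, from one ring amine to another, was within the scatter; no step covers a change to a chain with a hydrogen-bond donor, so the expectation leans on tolerance at this position alone. A modest weakening is expected, a 3.8-fold higher number from compound 1 to compound 3 (0.57 log units; beyond the scatter), with wide uncertainty. Compound 3 is estimated at 6 nM, between 1.5 nM and 25 nM.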

Compound 3, inhibition constant: "not active" (no number reported)
Nothing numeric was reported for compound 3, so the estimate cannot be set against anything.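

Within the data shown here, compound 3 is reported as not active, with no number, so no step from compound 1 to compound 3 can be read. On these data alone, whether any open chain at this position retains activity remains open. Nothing available bears on this result.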